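This account rests on a few compounds, and the source may have more. Where it says the series, first, only, none or still open, it means among the compounds named here.

Compound 2 `O=C(CCCCc1[nH]c2ccccc2c1C1=C(Br)C(=O)NC1=O)Nc1ccccc1` gives 2.56 in a physicochemical assay for lipophilicity (on this read-out higher numbers stand for higher lipophilicity and lower numbers for lower lipophilicity), and stands level, at the digits shown, with compound 1 `O=C(CCCc1[nH]c2ccccc2c1C1=C(Br)C(=O)NC1=O)Nc1ccccc1`, which gives 2.56; together these two are the lowest of the three numbers, and compound 3 `O=C(CCCCCc1[nH]c2ccccc2c1C1=C(Br)C(=O)NC1=O)Nc1ccccc1` gives 2.68. The steps of no change at the digits printed from compound 1 to compound 2 (within the scatter) and a number 0.12 log units higher from compound 2 to compound 3 (within the scatter) both stay within the scatter. Compound 4 `Cc1ccc(NC(=O)CCCc2[nH]c3ccccc3c2C2=C(Br)C(=O)NC2=O)cc1` differs from compound 2 by (4-methylphenyl)carbamoyl in place of (phenylcarbamoyl)methyl on a saturated chain carbon, three bonds along the chain from an aromatic carbon; the two hold the same atoms, joined differently. For the measured compounds named here, the chain part of this change mirrors the step from compound 1 to compound 2, which showed nothing beyond the scatter, while no measured step covers the methyl on the ring. Compound 4 is therefore expected to give 2.65, between 2.35 and 2.95. The estimated step of a number 0.09 log units higher from compound 2 to compound 4 (within the scatter) is expected to remain within the scatter.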

Compound 4, partition coefficient: 2.56
Estimate against measurement, compound 4: 0.09 log units above; low and high end bracket the measured number.
By their numbers in this assay, from the lowest: compounds 1, 2, 4 and 3 (each within the scatter of the next).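

In this assay, for the compounds shown here, methyl in place of hydrogen on an aromatic carbon, a change no earlier pair covered, gives no change at the digits printed from compound 1 to compound 4 (within the scatter). Placing the same atoms differently, with (4-methylphenyl)carbamoyl in place of (phenylcarbamoyl)methyl on a saturated chain carbon, three bonds along the chain from an aromatic carbon, gives no change at the digits printed from compound 2 to compound 4 (within the scatter), so these compounds do not separate an added carbon on the ring from one on the chain. Nothing measured here accounts for these numbers. From the compounds shown here alone, what stays open is whether a methoxy or a trifluoromethyl on that ring would leave the scatter. The same holds for an amine or a carboxylic acid on the chain.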